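Trifluoromethoxy in place of isopropyl on the distal aromatic ring

The compounds below may be only part of what the source reports. "The series", "measured", "known", "first", "only" and "open" are said of these compounds alone.

Measured so far:
compound 1, `COc1ncccc1-c1ccc(CO[C@H]2C[C@@H](N=C=S)C2)c(F)c1`, which in an assay on isolated protein for inhibition of N-acylethanolamine-hydrolyzing acid amidase (Homo sapiens), read by fluorescence, with a stated time of 90 min (on this read-out lower numbers stand for stronger inhibition and higher numbers for weaker inhibition), gives 304 nM
compound 2, `Fc1cc(-c2cccc(C(F)(F)F)c2)ccc1CO[C@H]1C[C@@H](N=C=S)C1`, which in this assay gives 67.2 nM
compound 3, `CC(C)c1ccc(-c2ccc(CO[C@H]3C[C@@H](N=C=S)C3)c(F)c2)cc1F`, which in this assay gives 227 nM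

Among these three numbers compound 3 holds the second highest. Its nearest neighbour is compound 1, whose number is only a little higher, a gap within the usual scatter, so the two cannot be told apart. Its furthest neighbour is compound 2, whose number is lower by a margin beyond the scatter.

Compound 4, `Fc1cc(-c2ccc(OC(F)(F)F)c(F)c2)ccc1CO[C@H]1C[C@@H](N=C=S)C1`, has not yet been measured in this assay. It differs from compound 3 in one place: trifluoromethoxy in place of isopropyl on an aromatic carbon. Among the compounds with values here, no pair of measured compounds differing in only one place is available, so the size of this step cannot be read from the data. The author expects the step from compound 3 to compound 4 in this assay to be a 1.7-fold lower number from compound 3 to compound 4 (0.24 log units; within the scatter), toward a lower number, modest and close to the edge of the scatter. Compound 4 is therefore estimated at 130 nM in this assay, with a range from 45 nM to 380 nM.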

Compound 4, half-maximal inhibitory concentration: 97.1 nM
Compound 4: the middle estimate sits 1.3-fold (0.13 log units) above what was measured; the range from low to high includes it.
By their numbers in this assay, from the lowest: compounds 2 and 4 (each within the scatter of the next); then compounds 3 and 1 (each within the scatter of the next).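

In this assay, trifluoromethoxy in place of isopropyl on this aromatic carbon, ortho to a fluoro group and para to a large group, gives a 2.3-fold lower number from compound 3 to compound 4 (0.37 log units; beyond the scatter). Within the data shown here, the earlier compounds offered no pair differing in one place, so this is the first sign that the read-out responds to the group at this position: 5 heavy atoms and a hydrogen-bond acceptor enter, while 3 heavy atoms and no acceptor leave. Nothing available here accounts for the direction or size of this step.

A single step cannot show which feature of the change matters, or whether the same step would hold on a different remainder of the molecule. As far as these compounds go, how an amine, a carboxylic acid or a longer alkyl chain on this carbon would read out remains open.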